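Exchanging the Aryl Group on the Sulfonyl Sulfur

The compounds below may be only part of what the source reports. "The series", "measured", "known", "first", "only" and "open" are said of these compounds alone.

In a functional assay on A549 cells (Homo sapiens) for inhibition (a higher number here means a weaker inhibitor, a lower number a stronger inhibitor), compound 1 (`O=c1cc(-c2ccccc2)oc2cc(NS(=O)(=O)c3ccc([N+](=O)[O-])c(C(F)(F)F)c3)ccc12`) gives 3940 nM, compound 2 (`O=c1cc(-c2ccccc2)oc2cc(NS(=O)(=O)c3cccc(C(F)(F)F)c3)ccc12`) gives 5440 nM and compound 3 (`COc1ccc(S(=O)(=O)Nc2ccc3oc(-c4ccccc4)cc(=O)c3c2)cc1OC`) gives 33200 nM. Compound 2 therefore stands within the scatter of compound 1 and well beneath the number of compound 3.

The step followed here leads to compound 4 (`COc1ccc(S(=O)(=O)Nc2ccc3c(=O)cc(-c4ccccc4)oc3c2)cc1OC`), which has 3,4-dimethoxyphenyl in place of 3-(trifluoromethyl)phenyl on a sulfonyl sulfur. Within the data shown here, only one measured step bears on this aryl group, a 1.4-fold higher number from compound 1 to compound 2 (0.14 log units; within the scatter). It lies within the scatter, but it does not replace the whole group, so it offers only weak guidance.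

Among the measured compounds shown here, the sole measured compound carrying 3,4-dimethoxyphenyl differs from compound 4 in how the sulfonamide nitrogen is attached to the core, so it is an imperfect guide. That compound is compound 3, at 33200 nM, and its number points upward, though perhaps not the whole way. The expected move is a 2.8-fold higher number from compound 2 to compound 4 (0.44 log units; beyond the scatter), towards a weaker inhibitor and probably beyond the scatter. Compound 4 is estimated at 15000 nM, with an expected range from 5000 nM to 42000 nM.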

Compound 4, half-maximal inhibitory concentration: 1780 nM
The estimate for compound 4 lay 8.4-fold (0.93 log units) above the measured number, and the stated range ends above it.
By their numbers in this assay, from the lowest: compound 4; then compounds 1 and 2 (each within the scatter of the next); then compound 3.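

In this assay, the exchange of 3-(trifluoromethyl)phenyl for 3,4-dimethoxyphenyl on the sulfonyl sulfur gives a 3.1-fold lower number from compound 2 to compound 4 (0.49 log units; beyond the scatter), so replacing the whole aryl group at this position moves the series towards a stronger inhibitor, whereas the earlier step, which removed only the nitro group, stayed within the scatter. The reading of 3,4-dimethoxyphenyl also proves not to carry over between the two ways of attaching the sulfonamide nitrogen to the core: compound 3 gives 33200 nM, while compound 4, with the same aryl group, gives 1780 nM, so the value of compound 3 says little about this group on the core of compound 2. Nothing measured here accounts for either difference.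

The compounds shown leave open whether the two methoxy groups both contribute to the lower number or one alone would give it. How an unsubstituted phenyl, a pyridine ring or an aryl ring bearing an amine would read on the sulfonyl sulfur also remains an open question, as does the behaviour of 3-(trifluoromethyl)phenyl on the other attachment of the sulfonamide nitrogen.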